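The source may report more compounds than this note shows. Statements on the series, on what has been measured and on what is new or still open speak of the compounds shown alone.

Compound 1 `N#C/C(=C\c1c(-c2ccccc2)[nH]c2ccccc12)C(=O)c1cccs1`: 1200 nM
Compound 2 `COCCOC(=O)/C(C#N)=C/c1c(-c2ccccc2)[nH]c2ccccc12`: 1600 nM

Both numbers come from a functional assay on CCRF-CEM cells (Homo sapiens) for cytotoxicity, read by MTT assay, with a stated time of 96 h; a lower number here means that less compound is needed, a higher number that more compound is needed for the effect. Compound 2 gives the higher of the two numbers, but the step of a 1.3-fold higher number from compound 1 to compound 2 (0.12 log units; within the scatter) lies within the scatter, so the two compounds cannot be told apart on these data. Compound 3 `N#C/C(=C\c1c(-c2ccccc2)[nH]c2ccccc12)C(=O)c1ccc(Cl)cc1` differs from compound 2 by 4-chlorophenyl in place of 2-methoxyethoxy on a carbonyl carbon. For the measured compounds named here, the only measured step that bears on a change on a carbonyl carbon of this shared core is a 1.3-fold higher number from compound 1 to compound 2 (0.12 log units; within the scatter), where thiophen-2-yl gave way to 2-methoxyethoxy without moving the number beyond the scatter. For the present step no movement beyond the scatter is therefore expected either, with compound 3 expected to land near compound 1 and compound 2, as an expected step of a 1.5-fold lower number from compound 2 to compound 3 (0.16 log units; within the scatter). The estimate for compound 3 is 1100 nM, with a range from 450 nM to 2700 nM.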

Compound 3, half-maximal effective concentration: 1100 nM
For compound 3 middle estimate and measured number coincide at the digits printed; low and high end bracket the measured number.
By their numbers in this assay, from the lowest: compounds 3, 1 and 2 (each within the scatter of the next).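

In this assay, 4-chlorophenyl on the carbonyl carbon adds a third kind of group at this place, and both new steps, a 1.5-fold lower number from compound 2 to compound 3 (0.16 log units; within the scatter) and a 1.1-fold lower number from compound 1 to compound 3 (0.04 log units; within the scatter), stay within the scatter. The earlier pair showed only that thiophen-2-yl and 2-methoxyethoxy could not be told apart; now a six-membered aromatic ring of carbon only, bearing chlorine, also cannot be told apart from either, so compounds 1, 2 and 3 read alike. Nothing available explains this lack of separation.

As far as these compounds go, whether an amine, a carboxylic acid or a longer chain on this carbonyl carbon would move the number beyond the scatter remains open. So does whether changes elsewhere on the shared core would do so, since all three compounds differ in this one place only.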